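A new aromatic group on compound 2

This account rests on a few compounds, and the source may have more. Where it says the series, first, only, none or still open, it means among the compounds named here.

In a functional assay on cells (Homo sapiens) for antiproliferative activity, read by MTT assay, with a stated time of 48 h (a higher number here means a weaker inhibitor, a lower number a stronger inhibitor), compound 1 (`CN(C)CCn1c(N)c(-c2nc3ccccc3s2)c2nc(C#N)c(C#N)nc21`) reaches only a limit, > 50000 nM. Compound 2 (`CN(C)CCCn1c(N)c(-c2nc3ccccc3s2)c2nc(C#N)c(C#N)nc21`) gives 2930 nM and compound 3 (`CN(C)CCCCn1c(N)c(-c2nc3ccccc3s2)c2nc(C#N)c(C#N)nc21`) gives 2740 nM, so these two stand within the scatter of each other. Compound 4 (`CN(C)CCCn1c(N)c(-c2nc3cc(Cl)ccc3[nH]2)c2nc(C#N)c(C#N)nc21`) carries 5-chloro-1H-benzimidazol-2-yl in place of the 1,3-benzothiazol-2-yl of compound 2: 5-chloro-1H-benzimidazol-2-yl in place of 1,3-benzothiazol-2-yl on an aromatic carbon. The measured steps, an at least 17-fold lower number from compound 1 to compound 2 (1.23 log units; beyond the scatter) and a 1.1-fold lower number from compound 2 to compound 3 (0.03 log units; within the scatter), alter only the chain and leave this aromatic group untouched, so neither gives a size for the exchange. No shift beyond the scatter is therefore expected, and the expected step is a 1.2-fold lower number from compound 2 to compound 4 (0.07 log units; within the scatter). Compound 4 is estimated at 2500 nM, with an expected range of 600 nM to 12000 nM.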

Compound 4, half-maximal inhibitory concentration: 28100 nM
Compound 4: middle estimate off by 11-fold (1.05 log units), on the low side; the measured number lies above the stated range.
By their numbers in this assay, from the lowest: compounds 3 and 2 (each within the scatter of the next); then compound 4. At a limit, above all of these: compound 1.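

In this assay, going by these compounds alone, the exchange of 1,3-benzothiazol-2-yl for 5-chloro-1H-benzimidazol-2-yl gives a 9.6-fold higher number from compound 2 to compound 4 (0.98 log units; beyond the scatter), so this aromatic group, untouched by the earlier steps, also moves the number. With the 3-(dimethylamino)propyl chain held constant, the change on this aromatic carbon alone weakens the compound. No measurement shown here bears on why. The exchange alters both the ring hetero atom and the chlorine, and the compounds shown do not separate the two. Unchlorinated 1H-benzimidazol-2-yl or 5-chloro-1,3-benzothiazol-2-yl would divide the step between them.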